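This account rests on a few compounds, and the source may have more. Where it says the series, first, only, none or still open, it means among the compounds named here.

In an in vivo ADME assay on the whole organism (strain Sprague-Dawley) for pharmacokinetics, with Rattus norvegicus as the target (on this read-out higher numbers stand for wider distribution into tissues and lower numbers for narrower distribution), compound 1 (`C[C@H](c1ccc(N2CC[C@H](NS(=O)(=O)c3ccc4cc(Cl)ccc4c3)C2=O)c(F)c1)N(C)C`) gives 1.3 L/kg and compound 2 (`C[C@@H](c1ccc(N2CC[C@H](NS(=O)(=O)c3ccc4cc(Cl)ccc4c3)C2=O)c(F)c1)N(C)C`) gives 1.8 L/kg on the same scale, which places compound 2 within the scatter of compound 1. Among the measured compounds shown here, the one measured step (a 1.4-fold higher number from compound 1 to compound 2 (0.14 log units; within the scatter)) rests on the fact that compounds 1 and 2 differ only in the configuration as drawn alone and so leaves the amine group untouched. Compound 3 (`CN[C@H](C)c1ccc(N2CC[C@H](NS(=O)(=O)c3ccc4cc(Cl)ccc4c3)C2=O)c(F)c1`) now changes that group. It carries 1-(methylamino)ethyl in place of 1-(dimethylamino)ethyl on an aromatic carbon, meta to a fluoro group and para to a large group (1-(methylamino)ethyl in place of 1-(dimethylamino)ethyl on an aromatic carbon). For the measured compounds named here, the measured step is therefore only a weak guide, since no measurement yet covers a change of this kind. With compound 2 at 1.8 L/kg as the starting point, no shift beyond the scatter is expected in this assay in either direction. The estimated move is small, namely a 1.1-fold higher number from compound 2 to compound 3 (0.05 log units; within the scatter) as expected here. For compound 3 the estimated value is 2 L/kg with an expected range from 1 L/kg to 3.8 L/kg in this read-out.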

Compound 3, volume of distribution at steady state: 2.4 L/kg
The estimate for compound 3 lay 1.2-fold (0.08 log units) below the measured number; the measured number falls inside the stated range.
By their numbers in this assay, from the lowest: compounds 1, 2 and 3 (each within the scatter of the next).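

The earlier pair could say nothing about the amine nitrogen, since its one step concerned configuration alone: the fact that compounds 1 and 2 differ only in the configuration as drawn

Among the compounds shown here, the new result gives the first reading on that nitrogen, on an aromatic carbon, meta to a fluoro group and para to a large group. In this assay, hydrogen in place of methyl on the amine nitrogen gives a 1.8-fold higher number from compound 1 to compound 3 (0.27 log units; within the scatter), and 1-(methylamino)ethyl in place of 1-(dimethylamino)ethyl gives a 1.3-fold higher number from compound 2 to compound 3 (0.12 log units; within the scatter). Both steps lie within the scatter, so this read-out does not separate the two groups here, even though 1-(methylamino)ethyl brings a hydrogen-bond donor that 1-(dimethylamino)ethyl lacks.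

The compounds shown leave open whether a 1-aminoethyl group, with a primary amine, would stay within the scatter as well, or whether a longer chain such as ethyl on the nitrogen, or a pyrrolidine ring built around it, would move the number beyond it. They also leave open how the mirror-image configuration at the chain carbon of 1-(methylamino)ethyl would read in this assay.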